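Swapping Fluoromethyl for Chloro on the Shared Core

The source may report more compounds than this note shows. Statements on the series, on what has been measured and on what is new or still open speak of the compounds shown alone.

Of the compounds shown here, three built on one core have been measured in an ADME assay on a cell-free system (plasma, Rattus norvegicus) for protein binding; on this read-out higher numbers stand for a larger free fraction and lower numbers for a smaller free fraction. Compound 1 `Cc1c(CF)nnc2sc(C(=O)NC3CN(c4ncc(C(F)(F)F)cn4)C3)c(N)c12` gives 0.034, the highest of the three numbers. Compound 2 `Cc1c(Cl)nnc2sc(C(=O)NC3CN(c4cc(C(F)(F)F)ncc4Cl)C3)c(N)c12` gives 0.019, which lies within the usual scatter of the value for compound 1. Compound 3 `COc1cc(N2CC(NC(=O)c3sc4nnc(Cl)c(C)c4c3N)C2)c(Cl)cn1` gives 0.005; going from compound 2 to compound 3 produced a 3.8-fold lower number from compound 2 to compound 3 (0.58 log units; beyond the scatter). Compound 4 `Cc1c(Cl)nnc2sc(C(=O)NC3CN(c4ncc(C(F)(F)F)cn4)C3)c(N)c12` differs from compound 1 by chloro in place of fluoromethyl on an aromatic carbon. Among the compounds with values here, no measured step covers this exact change: compound 2 already carries the chloro on the core but differs from compound 4 elsewhere, so only the closeness of compounds 1 and 2 offers a hint. A step near zero is therefore expected, a 1.1-fold lower number from compound 1 to compound 4 (0.05 log units; within the scatter). Compound 4 is estimated at 0.03, within 0.014 to 0.065.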

Compound 4, unbound fraction: 0.022
For compound 4 the middle estimate is 1.4-fold (0.13 log units) above the measured one; low and high end bracket the measured number.
By their numbers in this assay, from the lowest: compound 3; then compounds 2, 4 and 1 (each within the scatter of the next).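

The direct exchange of fluoromethyl for chloro on this aromatic carbon gives a 1.5-fold lower number from compound 1 to compound 4 (0.19 log units; within the scatter) in this assay, so at this position the two groups cannot be told apart on this read-out. The earlier compounds shown here offered only a hint, as no measured pair among them differed at this position alone. No measurement at hand offers an explanation for this result.

Only fluoromethyl and chloro can be compared at this position. From the compounds shown here alone, whether an amine, a carboxylic acid or a longer chain there would shift the unbound fraction beyond the scatter remains open.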